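Cytotoxicity notes on the amide side chain of compound 1

The source may report more compounds than this note shows. Statements on the series, on what has been measured and on what is new or still open speak of the compounds shown alone.

Compound 1 `Cc1cc(C)cc(S(=O)(=O)c2c(C(=O)NCc3ccc4nc(N)[nH]c4c3)[nH]c3ccc(Cl)cc23)c1` is the reference point of this short set. In an ADME assay on MT4 cells (Homo sapiens) for cytotoxicity, read by MTT assay (on this read-out higher numbers stand for lower toxicity in this test and lower numbers for higher toxicity in this test), compound 1 gives 5890 nM, the lowest of the two numbers recorded so far. For the measured compounds named here, compound 2 `Cc1cc(C)cc(S(=O)(=O)c2c(C(=O)NC(C)C(=O)NCc3ccncn3)[nH]c3ccc(Cl)cc23)c1` carries a different group on the amide-type nitrogen, and in this assay compound 2 gives 28100 nM; the step of a 4.8-fold higher number from compound 1 to compound 2 (0.68 log units; beyond the scatter) is the only measured step available. Compound 3 `Cc1cc(C)cc(S(=O)(=O)c2c(C(=O)NCC(=O)NC(C)c3ccccc3F)[nH]c3ccc(Cl)cc23)c1` is not yet measured. It differs from compound 1 as (1-(2-fluorophenyl)ethyl)carbamoyl in place of 2-amino-1H-benzimidazol-6-yl on a saturated chain carbon bound to an amide-type nitrogen. As in the step to compound 2, the 2-amino-1H-benzimidazol-6-yl group is removed and the chain is extended through a further amide, here carrying a (1-(2-fluorophenyl)ethyl)carbamoyl group. Going by the values given here, the one measured step thus bears on this change, though the entering group is not the same, so only its direction and rough size are borrowed from it. For compound 3 a step of a 2.5-fold higher number from compound 1 to compound 3 (0.41 log units; beyond the scatter) toward a higher number is expected in this assay, with wide uncertainty resting on a single precedent. Compound 3 is therefore estimated at 15000 nM, with a range from 5000 nM to 45000 nM.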

Compound 3, half-maximal cytotoxic concentration: 23000 nM
Estimate against measurement, compound 3: 1.5-fold (0.19 log units) below; the measured number falls inside the stated range.
By their numbers in this assay, from the lowest: compound 1; then compounds 3 and 2 (each within the scatter of the next).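

In this assay the replacement of 2-amino-1H-benzimidazol-6-yl by (1-(2-fluorophenyl)ethyl)carbamoyl, on a saturated chain carbon bound to an amide-type nitrogen, gives a 3.9-fold higher number from compound 1 to compound 3 (0.59 log units; beyond the scatter) and so points to lower toxicity in this test. Together with a 4.8-fold higher number from compound 1 to compound 2 (0.68 log units; beyond the scatter) there are now two steps away from compound 1, both beyond the scatter and both toward a higher number, so the direction no longer rests on one entering group: it holds with a six-membered aromatic ring of carbon only as well as with one carrying 2 hetero atoms, and no compound shown goes against it. No measured evidence bears on what lies behind this rise.

In both steps the amino group and the five-membered aromatic ring leave together, so the share of each in the change remains unresolved. As far as these compounds go, a benzimidazol-6-yl group without the amine, or a plain phenyl ring on the same chain carbon, would separate the two, while the part played by the fluorine and the methyl of the entering group also remains open.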